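Phenoxy for methylamino: expected clearance of compound 3

The source may hold more compounds than are shown below. What is called first, only, known or untested is meant among the compounds shown, and "the series" means these compounds.

Measured so far in an ADME assay (liver) for metabolic stability, with Liver microsome (Rattus norvegicus) as the target, using microsomes and NADPH, with a stated time of 30 min, at 37 degrees C, tested at 1 uM (on this read-out lower numbers stand for slow clearance and higher numbers for fast clearance), are two compounds:
- compound 1 `Nc1ccc(S(=O)(=O)c2ccc(-c3ncc(C(O)(C(F)(F)F)C(F)(F)F)cc3Cl)cc2)cn1` gives 18 mL.min-1.g-1 here
- compound 2 `CNc1nc(S(=O)(=O)c2ccc(N)nc2)ccc1-c1ccc(C(C)(O)C(F)(F)F)cn1` gives 21 mL.min-1.g-1 here

Compound 2 (21 mL.min-1.g-1) and compound 1 (18 mL.min-1.g-1) lie within the scatter of each other, so neither stands apart on these numbers. The next compound, compound 3 `CC(O)(c1ccc(-c2ccc(S(=O)(=O)c3ccc(N)nc3)nc2Oc2ccccc2)nc1)C(F)(F)F`, carries phenoxy in place of methylamino on an aromatic carbon of compound 2. Among the measured compounds shown here, no measured pair differs in one place, so the data offer no step for this change. In this assay a rise about as large as the scatter is expected, and this rests on the structural change and on compound 2 (21 mL.min-1.g-1) alone. The expected change is a 1.9-fold higher number from compound 2 to compound 3 (0.28 log units; within the scatter) in this read-out. For compound 3 the estimate is 40 mL.min-1.g-1 within an expected range from 16 mL.min-1.g-1 to 95 mL.min-1.g-1 as a working figure.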

Compound 3, intrinsic clearance in microsomes: 213 mL.min-1.g-1
The estimate for compound 3 lay 5.3-fold (0.73 log units) below the measured number; the whole stated range lies below it.
By their numbers in this assay, from the lowest: compounds 1 and 2 (each within the scatter of the next); then compound 3.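

In this assay, among the compounds shown here, phenoxy in place of methylamino on this aromatic carbon, next to the ring nitrogen, gives a 10-fold higher number from compound 2 to compound 3 (1.01 log units; beyond the scatter) and is the first single-place step. The step lies beyond the scatter, so the read-out depends on which of these two groups occupies this position on the core of compound 2. Nothing shown bears on the reason for this rise, which stands as an observation only.

For the compounds shown here, the single step does not separate the entering carbon ring from the oxygen that links it or from the loss of methylamino itself. Anilino would keep the ring with a nitrogen link, and methoxy would keep the oxygen without the ring, so either group at this position would bear on that open question.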